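This account rests on a few compounds, and the source may have more. Where it says the series, first, only, none or still open, it means among the compounds named here.

Working notes on the series. All four compounds share one core bearing a chloro-substituted aryloxyacetic acid and an alkyne link; they differ in the sulfonyl substituent and the ring group. Compound 1 `COCCN(C)S(=O)(=O)c1ccc(C)c(C#Cc2cc(Cl)ccc2OCC(=O)O)c1` and compound 2 `CCCS(=O)(=O)c1ccc(F)c(C#Cc2cc(Cl)ccc2OCC(=O)O)c1` have been run in an ADME assay on a cell-free system (plasma, Rattus norvegicus); a lower number here means a smaller unbound share, a higher number a larger unbound share of the compound: compound 1 gives 0.007, while compound 2 gives 0.004, and the two numbers sit within the scatter of each other, so no order between them is claimed. In this assay compound 3 `COCCNS(=O)(=O)c1ccc(C)c(C#Cc2cc(Cl)ccc2OCC(=O)O)c1` gives "not determined" (no result reported), so no number exists for it. Compound 4 `CN(C)S(=O)(=O)c1ccc(F)c(C#Cc2cc(Cl)ccc2OCC(=O)O)c1` is still to be measured. It differs from compound 2 by dimethylamino in place of propyl on a sulfonyl sulfur. Going by the values given here, with no step between measured pairs available, a step of a 1.3-fold higher number from compound 2 to compound 4 (0.10 log units; within the scatter) is expected, none beyond the scatter. Compound 4 is estimated at 0.005, within 0.002 to 0.012.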

Compound 4, unbound fraction: 0.007
The estimate for compound 4 lay 1.4-fold (0.15 log units) below the measured number; measured number inside the range.
By their numbers in this assay, from the lowest: compounds 2, 1 and 4 (each within the scatter of the next).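

Dimethylamino in place of propyl on a sulfonyl sulfur gives a 1.8-fold higher number from compound 2 to compound 4 (0.24 log units; within the scatter) in this assay. Going by these compounds alone, this is the only pair here that differs in one place, and it shows that exchanging propylsulfonyl for dimethylsulfamoyl on this core does not move the unbound fraction beyond the scatter. No measurement available here bears on the reason for this result. Still open, as far as these compounds go, is whether a longer chain than propyl on the sulfonyl sulfur would stay within the scatter. The same question holds for a cyclic amine such as morpholine in place of dimethylamino.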